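The source may hold more compounds than are shown below. What is called first, only, known or untested is meant among the compounds shown, and "the series" means these compounds.

Measured compounds:
compound 2 `Cc1cccc2nc(C#N)c([N+](=O)[O-])n12`: 1.19
compound 3 `Cc1cccc2nc(C(N)=O)c([N+](=O)[O-])n12`: 0.67
compound 1 `O=C(O)c1nc2ccccn2c1[N+](=O)[O-]`: -0.041

In a physicochemical assay for lipophilicity, measured as octanol-water partition (a higher number here means a more lipophilic compound, a lower number a more polar compound), compound 2 stands highest of the three numbers. Its nearest neighbour is compound 3, reached by the step of a number 0.52 log units lower from compound 2 to compound 3 (beyond the scatter); compound 1 lies furthest away, and its value sits well below that of compound 2.

The next compound, compound 4 `N#Cc1nc2ccccn2c1[N+](=O)[O-]`, has not yet been measured in this assay. It differs from compound 2 in a single place: hydrogen in place of methyl on an aromatic carbon.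

Among the compounds with values here, only one measured step exists, a number 0.52 log units lower from compound 2 to compound 3 (beyond the scatter), and it concerns carbamoyl in place of cyano, not the methyl. Within the data shown here, no measured pair differs only by a methyl group; compound 1 and compound 3 differ in two places, so their gap cannot be read as a single step. Since one carbon leaves and the remainder of compound 2 is untouched, a downward step is expected for compound 4, estimated as a number 0.49 log units lower from compound 2 to compound 4 (beyond the scatter), smaller than that single step but still beyond the scatter. For compound 4 the estimate in this assay is 0.7, between 0.4 and 1.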

Compound 4, partition coefficient: 0.691
Beside the measured number, compound 4's estimate is 0.01 log units above it; low and high end bracket the measured number.
By their numbers in this assay, from the lowest: compound 1; then compounds 3 and 4 (each within the scatter of the next); then compound 2.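

In this assay, within the data shown here, the methyl on the aromatic carbon next to the ring nitrogen now has a measured size: hydrogen in its place gives a number 0.50 log units lower from compound 2 to compound 4 (beyond the scatter) as the first single-place step at this position. Cyano in place of carboxy on an aromatic carbon, with no methyl on either side, gives a number 0.73 log units higher from compound 1 to compound 4 (beyond the scatter) as a second measured step for the group that earlier changed only from cyano to carbamoyl. Nothing available here accounts for the size of either step.

On these data alone, each change rests on a single pair, so it remains open whether the methyl step would keep its size with carbamoyl or carboxy on the shared core. As far as these compounds go, how an ethyl chain, a methoxy group or a chlorine atom in the methyl's place would shift the number also remains open.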